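A few compounds are considered here, and "the series" means these few. Any claim that something is new, unique, unknown or untested is made for them only; others in the source may bear on it.

In an ADME assay on microsomes from liver (Mus musculus) for metabolic stability, read by LC-MS, with a stated time of 4 h, tested at 1 uM (a higher number here means faster removal of the compound, a lower number slower removal), compound 1 `CCOc1nc(Cl)cc2nc(NCc3cc(C)c(-c4cn(C)nc4C)cn3)[nH]c12` gives 1370 mL/min/kg, and compound 2 `CCOc1cc(NC(=O)NCc2cc(C)c(-c3cn(C)nc3C)cn2)cc(Cl)n1` gives 700 mL/min/kg. Both of these compounds return numbers. Compound 3 `CCOc1cc(NC(=O)NCc2cc(C)c(-c3cn(C)nc3C(F)(F)F)nn2)cc(C)n1` returns no number at all, only a limit, recorded as < 58.4 mL/min/kg. From the compounds shown here alone, it therefore stands at the limit of < 58.4 mL/min/kg in this assay, at which 1 of the 3 values shown sits, and how far its true clearance lies from that limit is unknown.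

Compound 4 `CCOc1nc(C)cc(NC(=O)NCc2cc(C)c(-c3cn(C)nc3C(F)(F)F)nn2)c1Cl` is built directly on compound 3, and the one difference is chloro in place of hydrogen on an aromatic carbon. In words, this is chloro in place of hydrogen on an aromatic carbon, turning the 2-ethoxy-6-methylpyridin-4-yl group into a 3-chloro-2-ethoxy-6-methylpyridin-4-yl group. The new chloro sits ortho to the ethoxy group and para to the methyl group.

Among the compounds with values here, no pair of measured compounds here differs in a single place, so the data offer no direct precedent for this change. Going by these compounds, the expectation starts from the limit of compound 3, and its true distance from that limit remains open. The expected step, an at least 1.1-fold higher number from compound 3 to compound 4 (0.04 log units; that floor lies within the scatter), is small and slightly upward, with no move beyond the usual scatter foreseen. Compound 4 may itself return only a limit. If a number is returned, compound 4 is estimated at 65 mL/min/kg in this assay, with an expected range of 30 mL/min/kg to 180 mL/min/kg.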

Compound 4, clearance: 250 mL/min/kg
Compound 4: the middle estimate sits 3.8-fold (0.59 log units) below what was measured; measured number outside the range, above it.
By their numbers in this assay, from the lowest: compound 4; then compounds 2 and 1 (each within the scatter of the next). At a limit, below all of these: compound 3.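

In this assay, chloro in place of hydrogen on an aromatic carbon, ortho to an ethoxy group and para to a methyl group, gives an at least 4.2-fold higher number from compound 3 to compound 4 (0.63 log units; beyond the scatter). Within the data shown here, the position is therefore not indifferent to substitution: adding this single heavy atom moves the read-out beyond the usual scatter, which the earlier compounds could not show, as no two of them differed in only one place. The printed step is only a floor and its full size stays unknown, because compound 3 stands at a limit and not at a number: the limit of < 58.4 mL/min/kg in this assay, at which 1 of the 4 values shown sits.

The compounds shown leave open whether the rise belongs to chloro itself or would also follow from another small group on the same carbon, such as fluoro, a nitrile or a methoxy group. They also leave open whether the same change would act in the same direction on the core of compound 1 or of compound 2, and whether the other carbon of this ring that bears hydrogen would respond in the same way.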